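A few compounds are considered here, and "the series" means these few. Any claim that something is new, unique, unknown or untested is made for them only; others in the source may bear on it.

Measured so far in a functional assay on BMDM cells (Mus musculus, strain C57BL/6) for inhibition, with a stated time of 2 days; a higher number here means a weaker inhibitor, a lower number a stronger inhibitor:
compound 1, `COC(=O)c1ccc(-c2cn(CC(=O)Nc3nc(C)cs3)nn2)cc1`, gives > 30000 nM.
compound 2, `COc1ccc(-c2cn(CC(=O)Nc3nccs3)nn2)cc1`, gives 510 nM.
compound 3, `CCOC(=O)c1sc(NC(=O)Cn2cc(-c3ccc(OC)cc3)nn2)nc1C`, gives 2330 nM.

For compound 1 the reported value is a limit of this assay and not a number: the limit of > 30000 nM in this assay, at which 1 of the 3 values shown sits. Among the two compounds with a number, compound 3 stands highest; the nearest is compound 2, whose number is lower by a margin beyond the usual scatter. Within the data shown here, no pair of measured compounds differs in one place only, so no single step can be read off directly.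

Compound 4, `COc1ccc(-c2cn(CC(=O)Nc3nc(C)cs3)nn2)cc1`, is not yet measured in this assay. It is reached from compound 3 by hydrogen in place of ethoxycarbonyl on an aromatic carbon. Compound 4 thus keeps the methoxyphenyl and the amide of compound 2, and shares with compound 1 the methyl on the five-membered ring.

Expectation for the step from compound 3: a downward move in this assay, beyond the scatter, is expected, a 3.1-fold lower number from compound 3 to compound 4 (0.49 log units; beyond the scatter), since compound 2 with hydrogen at that ring position and the same methoxyphenyl gives 510 nM. Compound 4 is estimated at 750 nM, with a range from 250 nM to 2500 nM.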

Compound 4, half-maximal inhibitory concentration: 3890 nM
Compound 4: the middle estimate sits 5.2-fold (0.71 log units) below what was measured, outside the stated range (above it).
By their numbers in this assay, from the lowest: compound 2; then compounds 3 and 4 (each within the scatter of the next). At a limit, above all of these: compound 1.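

Hydrogen and ethoxycarbonyl on the aromatic carbon next to the ring sulfur are not told apart in this assay while the methyl group stays in place: a 1.7-fold higher number from compound 3 to compound 4 (0.22 log units; within the scatter). Among these compounds, the methyl group gives the first single-place reading at its own ring atom, with methyl in place of hydrogen on an aromatic carbon giving a 7.6-fold higher number from compound 2 to compound 4 (0.88 log units; beyond the scatter), so in this pair a change of only one heavy atom moves the number beyond the scatter, whereas the loss of ethoxycarbonyl with its 5 heavy atoms does not. Going by these compounds, compound 1 stands at a limit of this assay and not at a number, so methoxy in place of methoxycarbonyl on an aromatic carbon can be read only as a bound, an at least 7.7-fold lower number from compound 1 to compound 4 (0.88 log units; beyond the scatter), and the size of that step stays unknown: the limit of > 30000 nM in this assay, at which 1 of the 4 values shown sits.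

The compounds shown leave open whether a carboxylic acid, a primary amide or a longer alkyl chain at the ethoxycarbonyl position would also stay within the scatter of hydrogen. Also open, on these data alone, is whether ethyl or chlorine in place of the methyl group would move the number as far as methyl does, and whether ethoxycarbonyl would matter on a ring without the methyl group.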